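Swapping one aryl group on a growth inhibitor

A few compounds are considered here, and "the series" means these few. Any claim that something is new, unique, unknown or untested is made for them only; others in the source may bear on it.

Measured so far in a functional assay on M14 cells (Homo sapiens) for cytotoxicity; a higher number here means a weaker inhibitor of growth, a lower number a stronger inhibitor of growth:

Compound 1 `COc1ccc(C2=C(c3cc(OC)c(OC)c(OC)c3)CC3CCCN3C2=O)cc1O` gives > 100000 nM
Compound 2 `CSc1ccc(C2=C(c3ccc(F)c(C)c3)C(=O)N3CCCC3C2)cc1` gives 800 nM
Compound 3 `COc1ccc(C2=C(c3ccc(SC)cc3)CC3CCCN3C2=O)cc1OC` gives 5000 nM

The entry for compound 1 is a limit of the assay and not a number (> 100000 nM).

Within the data shown here, only two compounds therefore have real numbers to compare. Compound 2 has the lower of the two (800 nM), which makes it the stronger inhibitor of growth in this pair. Compound 3 stands higher (5000 nM), and that gap lies beyond the usual scatter of repeated measurements.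

Among the measured compounds shown here, the next compound to consider is compound 4 `CSc1ccc(C2=C(c3ccc(SC)cc3)C(=O)N3CCCC3C2)cc1`, which has no measurement yet. It differs from compound 2 in one place (4-(methylsulfanyl)phenyl in place of 4-fluoro-3-methylphenyl on a double-bonded ring carbon). A 4-(methylsulfanyl)phenyl group stands in place of 4-fluoro-3-methylphenyl on a double-bonded ring carbon, next to the ring atom that bears a 4-(methylsulfanyl)phenyl group.

For the measured compounds named here, no measured pair isolates this swap, so any forecast is rough. The best guide is the room between compound 2 (800 nM) and compound 3 (5000 nM). A modest rise in this assay is expected, meaning a somewhat weaker inhibitor (estimated step: a 1.9-fold higher number from compound 2 to compound 4 (0.27 log units; within the scatter)). Compound 4 is expected at 1500 nM (estimated range 300 nM to 8000 nM).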

Compound 4, concentration for 50% growth inhibition: 5000 nM
Estimate against measurement, compound 4: 3.3-fold (0.52 log units) below; the range from low to high includes it.
By their numbers in this assay, from the lowest: compound 2; then compounds 3 and 4 (each within the scatter of the next). At a limit, above all of these: compound 1.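

In this assay, the aryl group on this double-bonded ring carbon clearly matters: putting 4-(methylsulfanyl)phenyl in place of 4-fluoro-3-methylphenyl gives a 6.3-fold higher number from compound 2 to compound 4 (0.80 log units; beyond the scatter). Among these compounds, this is the first pair that differs in one place, so the weaker growth inhibition can be tied to this single swap, which the earlier comparison of values could not do. The two groups match in their count of heavy atoms and each is one six-membered aromatic ring of carbon only, yet they are not interchangeable here, although nothing measured for these compounds explains the difference.

On these data alone, it remains open whether the fluorine or the methyl of the departing group matters more, as a plain 4-fluorophenyl or 3-methylphenyl group at this carbon would separate the two. Also open, as far as these compounds go, is how this position responds to a group of a different kind, such as an aryl ring carrying an amine or a carboxylic acid, and whether the same swap has a similar effect when the neighbouring ring atom bears something other than 4-(methylsulfanyl)phenyl.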